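This account rests on a few compounds, and the source may have more. Where it says the series, first, only, none or still open, it means among the compounds named here.

Compound 1 `N#Cc1ccc(NC(=O)c2cc(Br)c3cccnc3c2O)cc1`: in a functional assay on HL-60 cells (Homo sapiens) for cytotoxicity, read by luminescence and CellTiter-Glo, with a stated time of 3 days (on this read-out higher numbers stand for weaker inhibition and lower numbers for stronger inhibition), compound 1 gives 330 nM.
Compound 2 `N#Cc1ccc(NC(=O)c2ccc3cccnc3c2O)cc1`: in this assay compound 2 gives 370 nM.
Compound 3 `N#Cc1ccc(NC(=O)c2ccc(-c3ccccc3)cc2O)cc1`: in this assay compound 3 gives 700 nM.

Compound 1 and compound 2 share one core and differ in a single place: bromo in place of hydrogen on an aromatic carbon. The step this makes in this assay is a 1.1-fold lower number from compound 2 to compound 1 (0.05 log units; within the scatter), so the two compounds cannot be told apart on this read-out. Compound 3 carries a different core; how the two cores differ is not broken down here. Its number in this assay lies higher than that of compound 1 by an amount beyond the scatter, while against compound 2 the gap stays within the scatter.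

Compound 4 `N#Cc1ccc(NC(=O)c2cc(Br)c(-c3ccccc3)cc2O)cc1` is built from compound 3 by the same kind of change that turns compound 2 into compound 1: bromo in place of hydrogen on an aromatic carbon. The surroundings are not identical, though. In compound 1 the bromo sits on a ring that is part of a fused or bridged system of two rings, ortho to a fused ring and meta to a fused ring; in compound 4 it sits ortho to a phenyl group on a ring that is not fused. In both cases it is meta to a large group and para to a hydroxy group.

Among the compounds with values here, since the one measured instance of this change, compound 2 to compound 1, gave a 1.1-fold lower number from compound 2 to compound 1 (0.05 log units; within the scatter), the step from compound 3 to compound 4 is expected to be similarly small, a 1.2-fold lower number from compound 3 to compound 4 (0.07 log units; within the scatter). Within the data shown here, compound 4 is therefore estimated at 600 nM in this assay, with a likely range of 250 nM to 1500 nM, resting on the single earlier instance and on the value of compound 3, 700 nM.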

Compound 4, half-maximal inhibitory concentration: 700 nM
For compound 4 the middle estimate is 1.2-fold (0.07 log units) below the measured one, and the stated range covers the measured number.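

Measured in this assay, bromo in place of hydrogen on an aromatic carbon makes no change at the digits printed from compound 3 to compound 4 (within the scatter), so on this core too the change leaves the read-out where it was. Set beside the earlier instance, the change gives the same result on the two cores: the same change on two cores in this assay, a 1.1-fold lower number (0.05 log units; within the scatter) from compound 2 to compound 1 and no change at the digits printed (within the scatter) from compound 3 to compound 4, 1.1-fold (0.05 log units) apart, within the scatter of two such steps This shows that, for these two pairs, the step carried over from one core to the other even though the surroundings of the bromo are not identical, but it rests on two small steps at a place that is meta to a large group and para to a hydroxy group in both, and it does not show that the change would stay this small on any other core or at any other place on the ring.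

The compounds shown leave open how a group other than bromo, such as an amine, a carboxylic acid or a longer alkyl chain, would fare at this same place on either core. They also leave open how far the number depends on the nitrile and the hydroxy group, which all four compounds carry.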